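Adding a methyl to the nitrogen of compound 2

This account rests on a few compounds, and the source may have more. Where it says the series, first, only, none or still open, it means among the compounds named here.

Measured in a functional assay on HL-60 cells (Homo sapiens) for antiproliferative activity, read by MTT assay, with a stated time of 72 h; a higher number here means a weaker inhibitor, a lower number a stronger inhibitor:
- Compound 1 `CNc1nc(-c2cc(OC)c(OC)c(OC)c2)c(-c2ccc(C(F)(F)F)cc2)s1`: 3170 nM
- Compound 2 `CNc1nc(-c2cc(OC)c(OC)c(OC)c2)c(-c2ccc(OC)cc2)s1`: 27.3 nM
- Compound 3 `CCOc1ccc(-c2sc(NC)nc2-c2cc(OC)c(OC)c(OC)c2)cc1`: 1.8 nM

Compound 2 sits in the middle of these three numbers. The step of a 120-fold lower number from compound 1 to compound 2 (2.06 log units; beyond the scatter) leads to it from above, and the step of a 15-fold lower number from compound 2 to compound 3 (1.18 log units; beyond the scatter) leads further down.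

Compound 4 `COc1ccc(-c2sc(N(C)C)nc2-c2cc(OC)c(OC)c(OC)c2)cc1` comes next, and its change is methyl in place of hydrogen on a nitrogen on an aromatic ring, so methylamino becomes dimethylamino.

Going by the values given here, no measured step touches that nitrogen. All three, including the step of a 1800-fold lower number from compound 1 to compound 3 (3.25 log units; beyond the scatter), alter a different group. Still, the step of a 15-fold lower number from compound 2 to compound 3 (1.18 log units; beyond the scatter) shows that an added methyl at another place in this small set can move the number beyond the scatter. It gives no direction for this nitrogen, so a moderate rise in this assay is only a cautious expectation, with a wide range.

The expected change is a 5.5-fold higher number from compound 2 to compound 4 (0.74 log units; beyond the scatter). Compound 4 is estimated at 150 nM, with an expected range from 15 nM to 1200 nM.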

Compound 4, half-maximal inhibitory concentration: 1890 nM
Estimate against measurement, compound 4: 13-fold (1.10 log units) below; measured number above the stated range.
By their numbers in this assay, from the lowest: compound 3; then compound 2; then compounds 4 and 1 (each within the scatter of the next).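

In this assay, this nitrogen proves to be a sensitive place: methylamino becoming dimethylamino gives a 69-fold higher number from compound 2 to compound 4 (1.84 log units; beyond the scatter), so one added methyl here moves the number a long way upward. An added methyl elsewhere went the other way, with a 15-fold lower number from compound 2 to compound 3 (1.18 log units; beyond the scatter), so in these compounds the outcome of adding a methyl depends on where it lands. Nothing available explains why this nitrogen responds so strongly.

The compounds shown leave open whether the change turns on the hydrogen that leaves or the methyl that enters; a plain amino group or an ethylamino group on this nitrogen would help separate the two. They also leave open whether the same change acts alike on the ethoxy compound 3.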